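The source may report more compounds than this note shows. Statements on the series, on what has been measured and on what is new or still open speak of the compounds shown alone.

Measured so far in an ADME assay on PC-3 cells (Homo sapiens) for cytotoxicity, read by WST assay, tested at 100 uM; on this read-out higher numbers stand for more inhibition at the one concentration tested (going by the name of the read-out) and lower numbers for less inhibition:

- compound 1, `Cc1nc(-c2cccc(NC(=O)C3CCCN(C(=O)c4cc(C(F)(F)F)cc(C(F)(F)F)c4)C3)c2)cs1`: 1%
- compound 2, `O=C(Nc1ccc(Cl)cc1)C1CCCN(C(=O)c2cccc(-c3cccs3)c2)C1`: 4%
- compound 3, `Cc1nc(-c2cccc(C(=O)N3CCCC(C(=O)Nc4ccc(Cl)cc4)C3)c2)cs1`: 1%

All three values sit within the usual scatter of one another. Compound 1 is indistinguishable from compound 3 at the digits shown, and the gap to compound 2 is also within the scatter, so nothing in this set separates the compounds on the read-out.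

Among the compounds with values here, the only measured step in this assay is a number 3 percentage points lower from compound 2 to compound 3 (within the scatter), a swap of one five-membered aromatic ring for another on the same aromatic carbon, and it lies within the scatter.

Compound 4, `O=C(Nc1cccc(-c2ccco2)c1)C1CCCN(C(=O)c2cc(C(F)(F)F)cc(C(F)(F)F)c2)C1`, is still to be measured. It differs from compound 1 as follows: furan-2-yl in place of 2-methyl-1,3-thiazol-4-yl on an aromatic carbon. This is again an exchange of one five-membered aromatic ring for another on an aromatic carbon of the same six-membered carbon ring, so the step between compound 2 and compound 3 is the relevant precedent, and that step was flat. No movement beyond the scatter is therefore expected in this assay . The step of a number 1 percentage points higher from compound 1 to compound 4 (within the scatter) is the estimate for this change. Compound 4 is thus expected to give about 2%, within -8% to 12%.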

Compound 4, a percentage reported as inhibition, at one concentration (the size of the read-out at that concentration, not a potency): 0%
The estimate for compound 4 lay 2 percentage points above the measured number; measured number inside the range.
By their numbers in this assay, from the lowest: compounds 4, 1, 3 and 2 (each within the scatter of the next).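

In this assay the exchange of 2-methyl-1,3-thiazol-4-yl for furan-2-yl gives a number 1 percentage points lower from compound 1 to compound 4 (within the scatter) and so leaves the read-out flat on the core of compound 1, meta to a large group. The earlier ring exchange, a number 3 percentage points lower from compound 2 to compound 3 (within the scatter), was read on a different core, so both available five-membered ring exchanges now lie within the scatter, even with the change from 6 heavy atoms to 5 and from 2 hydrogen-bond acceptors to 1 in the newer step. No measurement in hand bears on the reason for this flat result.

These steps cover five-membered aromatic rings only. On these data alone, whether an aminomethyl group or a carboxylic acid at this place would move the read-out beyond the scatter remains open.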